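The source may report more compounds than this note shows. Statements on the series, on what has been measured and on what is new or still open speak of the compounds shown alone.

Measured so far:
- compound 1 `O=Cc1cc(Br)c(O)c(O)c1Br` gives 31000 nM in a functional assay on DLD-1 cells (Homo sapiens) for cytotoxicity, read by MTT assay, with a stated time of 96 h; a lower number here means a stronger inhibitor, a higher number a weaker inhibitor
- compound 2 `CCOCc1cc(O)c(O)c(Br)c1` gives 35100 nM in this assay

On these two numbers compound 2 has the highest value, and its nearest neighbour is compound 1, whose number lies within the scatter of repeated measurements, so the two compounds cannot be told apart on potency in this assay. Both sit in the same weak range.

The next compound in the series is compound 3 `CCOCc1cc(Br)c(O)c(O)c1Br`, which follows from compound 2 by one change: bromo in place of hydrogen on an aromatic carbon. The change adds a single bromine to the shared core of compound 2 and leaves the two hydroxy groups and the ethoxymethyl group as they are.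

Going by the values given here, no measured step between two compounds that differ in a single place is available, so there is no basis for expecting more than a small shift. The expectation is that the step from compound 2 to compound 3 stays within the scatter, in either direction, and that compound 3 remains in the same weak range as compound 1 and compound 2 in this assay. The estimate for compound 3 is 30000 nM, with a range from 12000 nM to 75000 nM, which means an expected step of a 1.2-fold lower number from compound 2 to compound 3 (0.07 log units; within the scatter).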

Compound 3, half-maximal inhibitory concentration: 7150 nM
The estimate for compound 3 lay 4.2-fold (0.62 log units) above the measured number; measured number below the stated range.
By their numbers in this assay, from the lowest: compound 3; then compounds 1 and 2 (each within the scatter of the next).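

In this assay the series shows its first steps beyond the scatter, and both lead to compound 3. Bromo in place of hydrogen, on the aromatic carbon ortho to a hydroxy group and an ethoxymethyl group and para to a bromo group, gives a 4.9-fold lower number from compound 2 to compound 3 (0.69 log units; beyond the scatter) in this series, so this position responds to substitution when the ethoxymethyl group is present. Ethoxymethyl in place of formyl, with both bromo groups kept, gives a 4.3-fold lower number from compound 1 to compound 3 (0.64 log units; beyond the scatter) and shows that the other aromatic substituent also counts, with compound 3 alone among the three carrying both the second bromo and the ethoxymethyl group. No measurement at hand bears on the reason for either step.

From the compounds shown here alone, it remains open whether the step depends on bromine itself, which chloro, iodo or methyl on the same aromatic carbon would test. Going by these compounds, it is also open how far the ethoxymethyl group can be varied, for which a longer chain such as butoxymethyl, an aminomethyl group or a carboxylic acid in its place would give the comparison.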